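Ring enlargement at the hydroxyacetyl amide of compound 1

The source may hold more compounds than are shown below. What is called first, only, known or untested is meant among the compounds shown, and "the series" means these compounds.

Measured compounds:
compound 1 `CN1CCN(c2ccc(Nc3ncc4nc(Nc5ccc(F)cc5)n([C@H]5CCN(C(=O)CO)C5)c4n3)cc2)CC1` - "not determined" (no result reported)
compound 2 `CN1CCN(c2ccc(Nc3ncc4nc(Nc5ccc(F)cc5)n([C@H]5CCCC(NC(=O)OC(C)(C)C)C5)c4n3)cc2)CC1` - "not determined" (no result reported)
compound 3 `CN1CCN(c2ccc(Nc3ncc4nc(Nc5ccccc5)n([C@@H]5CCN(S(=O)(=O)C6CC6)C5)c4n3)cc2)CC1` - > 10000 nM

Compound 1 has no single number in a functional assay on A-431 cells (Homo sapiens) for antiproliferative activity, read by MTT assay, with a stated time of 72 h; a lower number here means a stronger inhibitor, a higher number a weaker inhibitor. Of the other entries, compound 2 has none either, and compound 3 gives only a limit of the assay, > 10000 nM, which is the limit of > 10000 nM in this assay, at which 1 of the 3 values shown sits. The new compound 4 `CN1CCN(c2ccc(Nc3ncc4nc(Nc5ccc(F)cc5)n([C@H]5CCCN(C(=O)CO)C5)c4n3)cc2)CC1` differs from compound 1 by 1-((hydroxymethyl)carbonyl)piperidin-3-yl in place of 1-((hydroxymethyl)carbonyl)pyrrolidin-3-yl on an aromatic nitrogen. Among the measured compounds shown here, no step between measured compounds is known, so no direction can be drawn from the data. The change is expected to make a small step, within the scatter, in this assay. For compound 4 the estimate is 5000 nM, expected between 500 nM and 50000 nM, with a fair chance that only a limit is reported.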

Compound 4, half-maximal inhibitory concentration: 3000 nM
Estimate against measurement, compound 4: 1.7-fold (0.22 log units) above; low and high end bracket the measured number.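

In this assay compound 4 gives 3000 nM, but compound 1 has no single number, so no step can be read between compound 1 and compound 4. The compounds shown leave open how 1-((hydroxymethyl)carbonyl)piperidin-3-yl compares with 1-((hydroxymethyl)carbonyl)pyrrolidin-3-yl on the shared core.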